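From Urea to Plain Benzamide on a Pyrazole Scaffold

The source may report more compounds than this note shows. Statements on the series, on what has been measured and on what is new or still open speak of the compounds shown alone.

Compound 1 `COc1cc(-c2nn(-c3cccc(NC(=O)c4ccc(Cl)c(C(F)(F)F)c4)c3)cc2-c2ccncc2)ccc1Cl`: > 32500 nM
Compound 2 `COc1cc(-c2nn(-c3cccc(NC(=O)Nc4ccc(Cl)c(C(F)(F)F)c4)c3)cc2-c2ccncc2)ccc1Cl`: 24700 nM
Compound 3 `COc1cc(-c2nn(-c3cccc(NC(=O)c4ccccc4)c3)cc2-c2ccncc2)ccc1Cl`: to be measured

In a functional assay on U-251 cells (Homo sapiens) for inhibition, read by sulforhodamine B assay, with a stated time of 48 h (on this read-out lower numbers stand for higher toxicity in this test and higher numbers for lower toxicity in this test), compound 1 gives only a limit, > 32500 nM, and no number. In this assay, going by the values given here, compound 2 gives 24700 nM, the only number among the two values shown. The step between them is an at least 1.3-fold lower number from compound 1 to compound 2 (0.11 log units; that floor lies within the scatter), and its floor is set by the limit of > 32500 nM in this assay, at which 1 of the 2 values shown sits.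

Compound 3 is the third member of the shared core. Against compound 2 the change is phenyl in place of (4-chloro-3-(trifluoromethyl)phenyl)amino on a carbonyl carbon. Among the compounds with values here, the one measured step that bears on it runs from the substituted benzamide of compound 1 to the urea of compound 2, and it is small. Compound 3 returns to the benzamide link while also dropping the chlorine and trifluoromethyl groups, so the expectation leans toward a value near compound 1, that is, weak toxicity or a limit. The expected step from compound 2 to compound 3 in this assay is a 1.4-fold higher number from compound 2 to compound 3 (0.15 log units; within the scatter). Compound 3 is therefore estimated at 35000 nM, within 12000 nM to 100000 nM.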

Compound 3, concentration lethal to 50% of the cells: > 100000 nM
Compound 3: a limit, no number; the forecaster's own chance of this, stated with the estimate: 55%; middle value at least 2.8-fold (0.45 log units) from the limit.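

In this assay, going by these compounds alone, replacing the (4-chloro-3-(trifluoromethyl)phenyl)amino group with phenyl on the carbonyl carbon gives the first step that is beyond the scatter: an at least 4.0-fold higher number from compound 2 to compound 3 (0.60 log units; beyond the scatter). The earlier step between the substituted benzamide and the urea had a floor within the scatter, so only now does the group on this carbonyl carbon show a readable link to the read-out, with the plain phenyl on the side of lower toxicity in this test. As far as these compounds go, compound 3 gives only a limit and not a number, so this step is a floor and its full size is unknown: the limit of > 100000 nM in this assay, at which 1 of the 3 values shown sits.

From the compounds shown here alone, the step from compound 1 to compound 3 cannot be read, as both values are limits, and the change from compound 2 to compound 3 removes the amino nitrogen, the chlorine and the trifluoromethyl together, so the share of each stays open. Also open, going by these compounds, is what an amine or a carboxylic acid on that phenyl ring would do to the value in this assay.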